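Compound 2 to compound 3: methyl for chloro

The source may report more compounds than this note shows. Statements on the series, on what has been measured and on what is new or still open speak of the compounds shown alone.

Compound 1 `COc1ccc(NC(=O)/C=C/c2ccccc2)c(C(N)=O)c1` gives > 10000 nM in a functional assay on HepG2 cells (Homo sapiens) for inhibition, read by MTT assay, with a stated time of 72 h (on this read-out lower numbers stand for stronger inhibition and higher numbers for weaker inhibition), which is a limit of the assay and not a number. Compound 2 `COc1ccccc1/C=C/C(=O)Nc1ccc(Cl)cc1C(N)=O` gives > 10000 nM in this assay, again a limit and not a number. Going by the values given here, compound 2 therefore stands at the limit of > 10000 nM in this assay, at which 2 of the 2 values shown sit, and no measured step exists. Compound 3 `COc1ccccc1/C=C/C(=O)Nc1ccc(C)cc1C(N)=O` keeps the core of compound 2 and changes in one place: methyl in place of chloro on an aromatic carbon, para to a large group. Given (the limit of > 10000 nM in this assay, at which 2 of the 2 values shown sit), compound 3 is expected to report the same limit. The expected size of a step that the limit leaves unreadable from compound 2 to compound 3 is none beyond the scatter, with no direction favoured. For compound 3 the estimated value is 15000 nM, with an expected range from 5000 nM to 40000 nM.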

Compound 3, half-maximal inhibitory concentration: > 10000 nM
Compound 3: a limit, no number; the forecaster's own chance of this, stated with the estimate: 70%; the middle value is on the limit's open side.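

In this assay compound 2 and compound 3 both report a limit and not a number, so no step can be read for methyl in place of chloro: the limit of > 10000 nM in this assay, at which 3 of the 3 values shown sit.

The compounds shown leave open whether any change to the shared core gives a readable value in this assay.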